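Comparing Amide Ends on a Shared Benzofuran-Free Core

The compounds below may be only part of what the source reports. "The series", "measured", "known", "first", "only" and "open" are said of these compounds alone.

For the measured compounds named here, compound 2 `CCCCc1oc2ccccc2c1C(=O)c1ccc(OCCCC(=O)N2CCCCC2)cc1` gives 16600 nM in a functional assay on U-937 cells (Homo sapiens) for antiproliferative activity, read by MTT assay, with a stated time of 24 h (on this read-out higher numbers stand for weaker inhibition and lower numbers for stronger inhibition), the lowest of the two numbers measured so far. Going by the values given here, compound 1 `CCCCc1oc2ccccc2c1C(=O)c1ccc(OCC(=O)N[C@H](C)c2ccccc2)cc1` gives 19800 nM in this assay; the only measured step, a 1.2-fold lower number from compound 1 to compound 2 (0.08 log units; within the scatter), lies within the scatter, so the two amide ends are indistinguishable on this read-out. Compound 3 `CCCCc1oc2ccccc2c1C(=O)c1ccc(OCCCC(=O)N(C)Cc2ccccc2)cc1` differs from compound 2 in one place: benzyl(methyl)amino in place of piperidin-1-yl on a carbonyl carbon. Among the compounds with values here, no measured step covers this exact change, and the one step that touched the amide end was flat, so no movement beyond the scatter is expected, a 1.2-fold lower number from compound 2 to compound 3 (0.07 log units; within the scatter). Compound 3 is therefore estimated at about 14000 nM, within 6000 nM to 35000 nM.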

Compound 3, half-maximal inhibitory concentration: 10500 nM
The estimate for compound 3 lay 1.3-fold (0.12 log units) above the measured number, within the range that was stated.
By their numbers in this assay, from the lowest: compounds 3, 2 and 1 (each within the scatter of the next).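

In this assay the swap to benzyl(methyl)amino from piperidin-1-yl on the carbonyl carbon gives a 1.6-fold lower number from compound 2 to compound 3 (0.20 log units; within the scatter), so at this position an open amide end carrying an aromatic ring cannot be told apart from a closed non-aromatic ring. Even with more heavy atoms entering than leaving, the number stays within the scatter. Nothing available explains this result. Still open, as far as these compounds go, is whether a carboxylic acid or a primary amine at this end, or a longer chain leading to the carbonyl, would move the number beyond the scatter.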